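The compounds below may be only part of what the source reports. "The series", "measured", "known", "first", "only" and "open" are said of these compounds alone.

Measured in a functional assay on A549 cells (Homo sapiens) for cytotoxicity, read by MTT assay, with a stated time of 72 h; on this read-out lower numbers stand for stronger inhibition and higher numbers for weaker inhibition:
- compound 1 `O=C(N/N=C/c1cccc(Br)c1)Nc1cc2c(Nc3ccc(F)c(Cl)c3)ncnc2cc1O[C@H]1CCOC1`: 10700 nM
- compound 2 `O=C(N/N=C/c1ccc(F)cc1Cl)Nc1cc2c(Nc3ccc(F)c(Cl)c3)ncnc2cc1O[C@H]1CCOC1`: 27200 nM
- compound 3 `COc1cc2ncnc(Nc3ccc(F)c(Cl)c3)c2cc1NC(=O)N/N=C/c1cccc(Br)c1`: 28100 nM

Compound 3 at 28100 nM and compound 2 at 27200 nM lie within the scatter of each other, and both numbers exceed that of compound 1. Compound 4 `COc1ccc(/C=N/NC(=O)Nc2cc3c(Nc4ccc(F)c(Cl)c4)ncnc3cc2OC)cc1` carries 4-methoxyphenyl in place of 3-bromophenyl on a carbon with a double bond to nitrogen. Going by the values given here, only one measured step changes that place: a 2.5-fold higher number from compound 1 to compound 2 (0.41 log units; beyond the scatter), which is modest. The other, a 2.6-fold higher number from compound 1 to compound 3 (0.42 log units; beyond the scatter), concerns the group on an oxygen on an aromatic ring, and compound 3 and compound 4 share that methyl. No direction can be drawn from this single step, so no change beyond the scatter is expected in this assay, with an estimated 1.1-fold higher number from compound 3 to compound 4 (0.03 log units; within the scatter). For compound 4 the expected value is 30000 nM, with an estimated range of 11000 nM to 75000 nM.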

Compound 4, half-maximal inhibitory concentration: 28100 nM
Beside the measured number, compound 4's estimate is 1.1-fold (0.03 log units) above it, and the stated range covers the measured number.
By their numbers in this assay, from the lowest: compound 1; then compounds 2, 3 and 4 (each within the scatter of the next).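

In this assay the change to 4-methoxyphenyl in place of 3-bromophenyl on a carbon with a double bond to nitrogen gives no change at the digits printed from compound 3 to compound 4 (within the scatter). So the added hydrogen-bond acceptor and the loss of bromine leave the number unmoved with methyl on the oxygen, whereas the only earlier step at this place, a 2.5-fold higher number from compound 1 to compound 2 (0.41 log units; beyond the scatter), lay beyond the scatter with oxolan-3-yl there. No measurement offered here explains this. The compounds shown leave open whether 4-methoxyphenyl would read the same with oxolan-3-yl on that oxygen, and how a phenyl ring carrying an amine or a carboxylic acid would fare at this place.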